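Swapping Phenoxy for Dimethylamino in a Kidney-Cell Toxicity Test

The source may hold more compounds than are shown below. What is called first, only, known or untested is meant among the compounds shown, and "the series" means these compounds.

Within the data shown here, compound 3 `Cc1cc(O)cc(-c2nn(CC#N)cc2-c2ccnc(-c3ccc(Oc4ccccc4)cc3)c2)c1` is the only member of this small set with a measured number in a functional assay on UO-31 cells (Homo sapiens) for inhibition, read by sulforhodamine B assay, with a stated time of 48 h; on this read-out higher numbers stand for lower toxicity in this test and lower numbers for higher toxicity in this test: compound 3 gives 31700 nM. Compound 1 `COc1cc(C)cc(-c2c(-c3ccnc(-c4ccc(C(C)=O)cc4)c3)cnn2CC#N)c1` reaches only a limit of the assay, > 100000 nM. Compound 2 `COc1cc(C)cc(-c2nn(CC#N)cc2-c2ccc(-c3cccc(C(C)=O)c3)nc2)c1` likewise stops at a limit, > 100000 nM. Among the measured compounds shown here, that is the limit of > 100000 nM in this assay, at which 2 of the 3 values shown sit, leaving compound 3 as the single value to build on. Compound 4 `Cc1cc(O)cc(-c2nn(CC#N)cc2-c2ccnc(-c3ccc(N(C)C)cc3)c2)c1` differs from compound 3 in one place: dimethylamino in place of phenoxy on an aromatic carbon. For the measured compounds named here, no measured pair shows what such a swap does here. The expected step from compound 3 to compound 4, a 1.6-fold higher number from compound 3 to compound 4 (0.20 log units; within the scatter), is small, towards lower toxicity, and may not exceed the scatter. Compound 4 is expected to give about 50000 nM, within 15000 nM to 100000 nM.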

Compound 4, concentration lethal to 50% of the cells: > 100000 nM
Compound 4 gave a limit, no number; the forecaster's own chance of this, stated with the estimate: 35%; at least 2.0-fold (0.30 log units) between middle value and limit.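

On the aromatic carbon para to a large group, replacing phenoxy with dimethylamino gives an at least 3.1-fold higher number from compound 3 to compound 4 (0.49 log units; beyond the scatter) in this assay, the first sign that this position can change the read-out. The result for compound 4 is a limit, so only the direction of the step, towards lower toxicity, is secure, not its full size. Compound 3 remains the only compound with a number: the limit of > 100000 nM in this assay, at which 3 of the 4 values shown sit.

From the compounds shown here alone, it remains open whether the aromatic ring of phenoxy is what counts here. A methoxy or cyclohexyloxy group at this position could help to separate the ring from the oxygen.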